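The compounds below may be only part of what the source reports. "The series", "measured", "known", "first", "only" and "open" are said of these compounds alone.

Among the compounds with values here, compound 1 `CN(C)c1ccc(/C=C(/SCc2ccc(F)cc2)C(=O)c2ccc(Br)cc2)cc1` is one of two compounds measured in a functional assay on DU-145 cells (Homo sapiens) for inhibition, read by trypan blue exclusion, with a stated time of 96 h (on this read-out higher numbers stand for weaker inhibition of growth and lower numbers for stronger inhibition of growth), where compound 1 gives 50000 nM, the highest of the two numbers. Its nearest neighbour, compound 2 `CN(C)c1ccc(/C=C(/SCc2ccc(Cl)cc2)C(=O)c2ccc(Br)cc2)cc1`, gives 10000 nM in this assay. Within the data shown here, the only measured step, a 5.0-fold lower number from compound 1 to compound 2 (0.70 log units; beyond the scatter), concerns a chloro in place of fluoro on an aromatic carbon and so touches a part of the molecule that stays the same here.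

Compound 3 `O=C(/C(=C\c1c[nH]c2ccc(Cl)cc12)SCc1ccc(F)cc1)c1ccc(Br)cc1` differs from compound 1 at a different place: 5-chloro-1H-indol-3-yl in place of 4-(dimethylamino)phenyl on a double-bonded chain carbon bound to a double-bonded chain carbon. Among the measured compounds shown here, no measured step covers this kind of change, so the direction of the step in this assay cannot be read from the data, and only a modest step in either direction, if any, is expected. The expected step is a 2.0-fold lower number from compound 1 to compound 3 (0.30 log units; within the scatter). Compound 3 is therefore estimated to give about 25000 nM in this assay, most likely between 5000 nM and 100000 nM.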

Compound 3, concentration for 50% growth inhibition: 1000 nM
Compound 3: middle estimate off by 25-fold (1.40 log units), on the high side; the whole stated range lies above it.
By their numbers in this assay, from the lowest: compound 3; then compound 2; then compound 1.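

In this assay this double-bonded chain carbon proves a far more sensitive place than the aromatic carbon of the earlier step: 5-chloro-1H-indol-3-yl in place of 4-(dimethylamino)phenyl gives a 50-fold lower number from compound 1 to compound 3 (1.70 log units; beyond the scatter) as a large step, against a 5.0-fold lower number from compound 1 to compound 2 (0.70 log units; beyond the scatter) as a modest step for chloro in place of fluoro. The swap changes several things at once, since a five-membered aromatic ring, a chlorine and a hydrogen-bond donor enter while a hydrogen-bond acceptor leaves, so the numbers cannot assign the step to any one of them. No measurement at hand explains its size.

Still open, from the compounds shown here alone, is how a plain 1H-indol-3-yl without the chlorine, or one carrying a methoxy group in its place, would read in this assay and so whether the chlorine is needed for the step. Also open, going by these compounds, is whether chloro in place of fluoro would lower the number again on the core of compound 3.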